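The source may hold more compounds than are shown below. What is called first, only, known or untested is meant among the compounds shown, and "the series" means these compounds.

Measured compounds in this series:

- compound 1, `CCCCCCCCNC(=S)N1[C@H](CO)[C@@H](O)[C@H](O)[C@H]1CO`: 414000 nM
- compound 2, `CCCC/N=C1/SC[C@H]2[C@H](O)[C@@H](O)[C@H](CO)N12`: 719000 nM
- compound 3, `CCCCNC(=S)N1[C@@H](CO)[C@H](O)[C@@H](O)[C@@H]1CO`: 473000 nM

In an assay for inhibition of beta-galactosidase (Bos taurus), read by spectrophotometry (a higher number here means a weaker inhibitor, a lower number a stronger inhibitor), compound 2 gives the highest of the three numbers, with compound 3 the nearest and compound 1 the furthest; both gaps lie within the usual scatter, so no order among the three can be claimed. Compound 1 and compound 3 share a core and differ only in the chain on the thiourea nitrogen; their two values in this assay sit within the scatter of each other.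

Compound 4, `CCCCCCCCCCCC/N=C1/SC[C@H]2[C@H](O)[C@@H](O)[C@H](CO)N12`, has not yet been measured. Relative to compound 2 the change is octyl in place of hydrogen on a saturated chain carbon, four bonds along the chain from a double-bonded nitrogen. Among the compounds with values here, no step between measured compounds that differ in one place is available for this series. Given that compound 1 and compound 3 show no difference beyond the scatter for a comparable chain extension, the step from compound 2 to compound 4 in this assay is expected to be a 1.1-fold lower number from compound 2 to compound 4 (0.04 log units; within the scatter), that is, none beyond the scatter. Compound 4 is accordingly estimated at 650000 nM, within a range of 250000 nM to 1700000 nM.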

Compound 4, half-maximal inhibitory concentration: 11000 nM
Compound 4: the middle estimate sits 59-fold (1.77 log units) above what was measured, outside the stated range (below it).
By their numbers in this assay, from the lowest: compound 4; then compounds 1, 3 and 2 (each within the scatter of the next).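

In this assay octyl in place of hydrogen on a saturated chain carbon, four bonds along the chain from a double-bonded nitrogen, gives a large step (a 65-fold lower number from compound 2 to compound 4 (1.82 log units; beyond the scatter)), so this position on the chain of compound 2 can carry a change that moves the number well beyond the scatter. The three earlier compounds all lay within the scatter of one another and gave no sign of such a step. No measurement in hand accounts for the size of this step.

From the compounds shown here alone, whether the number follows chain length in a graded way or changes abruptly stays open, as a hexyl or a longer hexadecyl chain at this place would test. Also open, going by these compounds, is whether the step survives with an amine or a carboxylic acid at the end of the chain.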